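The source may report more compounds than this note shows. Statements on the series, on what has been measured and on what is new or still open speak of the compounds shown alone.

Measured so far in a functional assay on A549 cells (Homo sapiens) for cytotoxicity, read by MTT assay, with a stated time of 48 h; a higher number here means a weaker inhibitor, a lower number a stronger inhibitor:
Compound 1, `Cc1ccc(-c2csc(NC(=O)COc3ccccc3C)n2)cc1`, gives 50900 nM.
Compound 2, `Cc1ccc(-c2csc(NC(=O)COc3ccccc3C(C)C)n2)cc1`, gives 44200 nM.
Compound 3, `Cc1ccccc1OCC(=O)Nc1nc(-c2ccc(Br)cc2)cs1`, gives 50100 nM.

Compound 1 carries the highest of the three numbers in this assay, but its neighbours sit close: a 1.0-fold lower number from compound 1 to compound 3 (0.01 log units; within the scatter) and a 1.2-fold lower number from compound 1 to compound 2 (0.06 log units; within the scatter). All three values lie within the scatter of one another, so no order among them can be read.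

Compound 4, `Cc1ccc(OCC(=O)Nc2nc(-c3ccc(C)cc3)cs2)cc1`, is not yet measured. It differs from compound 1 by 4-methylphenyl in place of 2-methylphenyl on an oxygen on a saturated carbon. Going by the values given here, no measured pair shows this change. The step from compound 1 to compound 2 touches the same ring and was within the scatter; the step from compound 1 to compound 3 sits on the other aryl and was also within the scatter. Neither bears directly on moving the methyl, and nothing in the series points to a shift in this assay beyond the scatter, in either direction.

Compound 4 is therefore expected at 50000 nM, within 25000 nM to 100000 nM, an expected step of a 1.0-fold lower number from compound 1 to compound 4 (0.01 log units; within the scatter).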

Compound 4, half-maximal inhibitory concentration: 48300 nM
Estimate against measurement, compound 4: 1.0-fold (0.02 log units) above; measured number inside the range.
By their numbers in this assay, from the lowest: compounds 2, 4, 3 and 1 (each within the scatter of the next).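

Moving the methyl turns 2-methylphenyl into 4-methylphenyl on the oxygen on a saturated carbon and gives a 1.1-fold lower number from compound 1 to compound 4 (0.02 log units; within the scatter) in this assay, so in this series the place of the methyl on this ring has no readable effect on the number. Going by these compounds alone, earlier, the only change on this ring was the group itself, with a 1.2-fold lower number from compound 1 to compound 2 (0.06 log units; within the scatter); the new step adds a change of where the group stands, and it too cannot be told apart from repeat measurements. Nothing measured alongside these numbers bears on this result or offers an account of it.

Going by these compounds, whether any group on this ring can shift the number beyond the scatter stays open, since only small alkyl groups appear there. An amine or a carboxylic acid on this ring, or a longer chain in place of the methyl, would test that.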